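This account rests on a few compounds, and the source may have more. Where it says the series, first, only, none or still open, it means among the compounds named here.

Going by the values given here, compound 2 `O=C(O)COc1cc(=O)oc2cc(OCc3cccc(Cl)c3)ccc12` stands at the lowest number of the two compounds measured so far: in an assay on isolated protein (strain Sprague-Dawley) for inhibition of Amine oxidase [flavin-containing] A (Rattus norvegicus), read by spectrophotometry, with a stated time of 5 min, tested at 10 uM (on this read-out lower numbers stand for less inhibition and higher numbers for more inhibition at the one concentration tested (going by the name of the read-out)), compound 2 gives 0%, whereas compound 1 `COc1cc(=O)oc2cc(OCc3cccc(F)c3)ccc12` gives 49% in this assay, a gap beyond the usual scatter. Compound 3 `N#Cc1cc(=O)oc2cc(OCc3cccc(Cl)c3)ccc12` has not yet been measured. Going from compound 2 to compound 3, the change is cyano in place of carboxymethoxy on an aromatic carbon. Given that compound 2 gives 0% while compound 1 gives 49%, an upward step is expected rather than none: a number 50 percentage points higher from compound 2 to compound 3 (beyond the scatter). Compound 3 is estimated to give 50%, with a likely range from 20% to 80%.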

Compound 3, a percentage reported as inhibition, at one concentration (the size of the read-out at that concentration, not a potency): 23%
Estimate against measurement, compound 3: 27 percentage points above, within the range that was stated.
By their numbers in this assay, from the lowest: compound 2; then compound 3; then compound 1.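

In this assay, cyano in place of carboxymethoxy on this aromatic carbon, opposite the ring oxygen, gives a number 23 percentage points higher from compound 2 to compound 3 (beyond the scatter). Going by these compounds alone, this is the first pair differing in one place only, so it shows that the group on this carbon alone can change the read-out while the rest of the molecule stays the same. Nothing measured here explains why the number moves. A single swap cannot separate the loss of carboxymethoxy from the gain of cyano. Going by these compounds, how an amine or an amide on this carbon would read remains open.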